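Amide in place of the ester on the quinoline series

The compounds below may be only part of what the source reports. "The series", "measured", "known", "first", "only" and "open" are said of these compounds alone.

Compound 2 `CCOC(=O)c1c(CN(CC)Cc2ccccc2)nc2ccccc2c1-c1ccccc1` gives 700 nM in an assay on brain with Translocator protein (Rattus norvegicus) as the target (a higher number here means a weaker inhibitor, a lower number a stronger inhibitor), which is the lowest of the two numbers recorded for it. Compound 3 `CCOC(=O)c1c(CN2CCc3ccccc3C2)nc2ccccc2c1-c1ccccc1` gives 1190 nM in this assay, and the step of a 1.7-fold higher number from compound 2 to compound 3 (0.23 log units; within the scatter) shows that the amine exchange is of little consequence. Compound 1 `Cc1nc2ccccc2c(-c2ccccc2)c1C(=O)N(C)c1ccccc1`, the only amide measured so far, gives only > 10000 nM in this assay, a limit of the measurement rather than a number (the limit of > 10000 nM in this assay, at which 1 of the 3 values shown sits). Compound 4 `CCN(Cc1ccccc1)Cc1nc2ccccc2c(-c2ccccc2)c1C(=O)N(C)c1ccc(Cl)cc1` is not yet measured. It keeps the amine of compound 2 and changes the carbonyl substituent: (4-chlorophenyl)(methyl)amino in place of ethoxy on a carbonyl carbon. For the measured compounds named here, no measured step covers this exchange alone; compound 1 differs from compound 2 in two places, so its limit can only be noted. Going by the values given here, the one measured step, from compound 2 to compound 3, is within the scatter and lies elsewhere in the molecule. The expectation for compound 4 in this assay is therefore a weaker number than compound 2, a 2.9-fold higher number from compound 2 to compound 4 (0.46 log units; beyond the scatter), with wide uncertainty. Compound 4 is estimated at 2000 nM, between 300 nM and 15000 nM.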

Compound 4, half-maximal inhibitory concentration: 2480 nM
Compound 4: middle estimate off by 1.2-fold (0.09 log units), on the low side; the range from low to high includes it.
By their numbers in this assay, from the lowest: compounds 2 and 3 (each within the scatter of the next); then compound 4. At a limit, above all of these: compound 1.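

In this assay, the ethoxy group on the carbonyl carbon can be exchanged for (4-chlorophenyl)(methyl)amino with the amine of compound 2 kept, and the result is still a number rather than a limit: a 3.5-fold higher number from compound 2 to compound 4 (0.55 log units; beyond the scatter). For the compounds shown here, this is the first measured change at this position, and unlike the amine exchange, a 1.7-fold higher number from compound 2 to compound 3 (0.23 log units; within the scatter), it lies beyond the scatter. Compound 1 stays a limit of the assay and differs from compound 4 in more than one place, so the amide alone cannot be held to account for it: the limit of > 10000 nM in this assay, at which 1 of the 4 values shown sits.

The compounds shown do not separate the contribution of the chlorine from that of the amide, which a plain N-methyl-N-phenyl amide carrying the same amine would address. Also open, as far as these compounds go, are a carboxylic acid on this carbonyl carbon and the 1,2,3,4-tetrahydroisoquinolin-2-yl group on the amide series.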